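A carbonyl arrives: what to expect of compound 4

The compounds below may be only part of what the source reports. "The series", "measured", "known", "first", "only" and "open" are said of these compounds alone.

Values in a functional assay on A549 cells (Homo sapiens) for antiproliferative activity, read by MTT assay, with a stated time of 24 h; on this read-out lower numbers stand for stronger inhibition and higher numbers for weaker inhibition:
Compound 1 `Cc1ccccc1NNC(=O)c1ccc(NS(=O)(=O)c2cnc(O)nc2O)cc1`: 14500 nM
Compound 2 `Cc1cccc(NNC(=O)c2ccc(NS(=O)(=O)c3cnc(O)nc3O)cc2)c1`: > 20000 nM (a limit)
Compound 3 `O=C(NNc1ccc(F)cc1)c1ccc(NS(=O)(=O)c2cnc(O)nc2O)cc1`: > 20000 nM (a limit)

Compound 3 stands at the limit of > 20000 nM in this assay, at which 2 of the 3 values shown sit, so it offers a limit and not a number. Compound 4 `O=C(NNC(=O)c1cccc(Cl)c1)c1ccc(NS(=O)(=O)c2cnc(O)nc2O)cc1` carries (3-chlorophenyl)carbonyl in place of 4-fluorophenyl on an amine nitrogen. Two measured steps change the group on this same nitrogen. The first is an at least 1.3-fold higher number from compound 1 to compound 3 (0.13 log units; that floor lies within the scatter), and the second is a step that the two limits leave unreadable from compound 2 to compound 3. Neither step brings a carbonyl onto that nitrogen, so they are only a weak guide. Compound 1 alone gives a true number, 14500 nM. No change beyond the scatter is therefore expected in this assay, and another limit is quite possible. The expected result is a number no higher from compound 3 to compound 4 (the limit leaves the size open). The estimate for compound 4 is 20000 nM, with an expected range of 9000 nM to 45000 nM.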

Compound 4, half-maximal inhibitory concentration: 2290 nM
Beside the measured number, compound 4's estimate is 8.7-fold (0.94 log units) above it; measured number outside the range, below it.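

In this assay, among these compounds, the earlier swaps among substituted phenyl groups on this amine nitrogen gave no step readable beyond the scatter, whereas (3-chlorophenyl)carbonyl brings a clear change. Among the compounds shown here, it gives an at least 8.7-fold lower number from compound 3 to compound 4 (0.94 log units; beyond the scatter) and an at least 8.7-fold lower number from compound 2 to compound 4 (0.94 log units; beyond the scatter) and also a 6.3-fold lower number from compound 1 to compound 4 (0.80 log units; beyond the scatter) in the one comparison that joins two true numbers. The first two steps show only the smallest possible size, because compound 2 and compound 3 each stand at a limit and not at a number: the limit of > 20000 nM in this assay, at which 2 of the 4 values shown sit.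

Compound 4 brings the carbonyl and the chlorine in a single change, and the compounds shown do not separate the two. Going by these compounds, how this nitrogen would fare with a plain benzoyl group, with no chlorine, or with an acetyl group remains open.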